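Pentyl on selenium: compound 3 to compound 4

The source may hold more compounds than are shown below. What is called first, only, known or untested is meant among the compounds shown, and "the series" means these compounds.

Measured compounds in a functional assay on HT-29 cells (Homo sapiens) for cytotoxicity, read by MTT assay, with a stated time of 72 h; on this read-out lower numbers stand for higher toxicity in this test and higher numbers for lower toxicity in this test:
- compound 1 `CCCCC[Se]c1nc([Se]CCCCC)c2ccccc2n1`, > 100000 nM, a limit of the assay
- compound 2 `CCCCC[Se]c1nc(NCc2ccccc2)c2ccccc2n1`, > 100000 nM, a limit of the assay
- compound 3 `Nc1nc([SeH])nc2ccccc12`, > 100000 nM, a limit of the assay

Compound 3 stands only at a limit of this assay, not at a number. Among the compounds with values here, the one step between measured compounds, a step that the two limits leave unreadable from compound 1 to compound 2, is unreadable in size because both ends sit at a limit; the shared picture is the limit of > 100000 nM in this assay, at which 3 of the 3 values shown sit.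

Compound 4 `CCCCC[Se]c1nc(N)c2ccccc2n1` has not yet been measured. It differs from compound 3 by pentyl in place of hydrogen on a selenium. Within the data shown here, no measured step follows this change; the only step on record concerns a different position and is unreadable in size. With all three values at the same limit, no direction can be derived, and no step beyond the scatter is expected. Compound 4 is therefore expected to give 100000 nM (range 40000 nM to 300000 nM) in this assay, most likely again as a limit. The step of a number no higher from compound 3 to compound 4 (the limit leaves the size open) is an estimate only.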

Compound 4, concentration lethal to 50% of the cells: > 100000 nM
Compound 4: no number, only a limit; the forecaster's own chance of this, stated with the estimate: 80%; the middle value lies on the limit itself.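

In this assay, the steps joining compound 4 to compound 1, compound 2 and compound 3 cannot be read, since every value is a limit: the limit of > 100000 nM in this assay, at which 4 of the 4 values shown sit.

The compounds shown leave open whether any change in this series gives a number rather than a limit, and how large any step would be.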